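This account rests on a few compounds, and the source may have more. Where it says the series, first, only, none or still open, it means among the compounds named here.

Compound 1 `CC1CCN(c2nc(C(F)(F)F)ccc2CNC(=O)C(C)c2ccc3c(c2)CCC3)CC1` carries a trifluoromethyl group on its pyridine-type core and, in an assay on CHO-K1 cells for antagonist activity at transient receptor potential cation channel subfamily V member 1 (Homo sapiens), read by FLIPR (a lower number here means a stronger inhibitor, a higher number a weaker inhibitor), compound 1 gives 57.4 nM. Within the data shown here, the only other compound measured, compound 2 `CC1CCN(c2nc(C(F)(F)F)ccc2CNC(=O)C(C)c2ccc3c(c2)CCO3)CC1`, differs at the bicyclic end of the molecule, and in this assay compound 2 gives 29.7 nM. The two are separated only by a 1.9-fold lower number from compound 1 to compound 2 (0.29 log units; within the scatter), so neither can be called the stronger inhibitor on these numbers.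

Compound 3 `CC1CCN(c2nc(C(C)(C)C)ccc2CNC(=O)C(C)c2ccc3c(c2)CCC3)CC1` instead changes the other end of compound 1: tert-butyl in place of trifluoromethyl on an aromatic carbon, next to the ring nitrogen, meta to a 4-methylpiperidin-1-yl group and para to a large group. Among the measured compounds shown here, no measured step touches this position, so the single known step gives no guide to its size; it only shows that a nearby swap of equal atom count stayed within the scatter. Compound 3 is therefore expected to give 85 nM, between 25 nM and 300 nM. The expected step of a 1.5-fold higher number from compound 1 to compound 3 (0.17 log units; within the scatter) is modest and uncertain.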

Compound 3, inhibition constant: 44 nM
Compound 3: the middle estimate sits 1.9-fold (0.29 log units) above what was measured, and the stated range covers the measured number.
By their numbers in this assay, from the lowest: compounds 2, 3 and 1 (each within the scatter of the next).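

In this assay, tert-butyl in place of trifluoromethyl on this aromatic carbon gives a 1.3-fold lower number from compound 1 to compound 3 (0.12 log units; within the scatter) and so shows that this position takes either group with no difference that can be told apart from the scatter. The two groups have the same number of heavy atoms and no hydrogen-bond donors or acceptors, but one is all carbon and the other carries three fluorine atoms, and that swap of atoms leaves the reading within the scatter. No measurement is available that could explain why the two compounds read alike.

From the compounds shown here alone, it remains open whether an amine, a carboxylic acid or a single chlorine atom on this carbon would also stay within the scatter. Going by these compounds, it is equally open whether tert-butyl would read the same alongside the bicyclic end of compound 2.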